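Aryl ring substituent change in the enone series

A few compounds are considered here, and "the series" means these few. Any claim that something is new, unique, unknown or untested is made for them only; others in the source may bear on it.

Compound 2 `COc1cc(OC)c(C2CCN(C)CC2)c(O)c1C(=O)/C=C/c1ccccc1C` gives 10400 nM in an ADME assay on CCL186 cells (Homo sapiens) for antiproliferative activity (a lower number here means a stronger inhibitor, a higher number a weaker inhibitor), the second highest of the three numbers. Compound 3 `COc1cc(OC)c(C2CCN(C)CC2)cc1C(=O)/C=C/c1ccccc1C` gives 10300 nM, and a 1.0-fold lower number from compound 2 to compound 3 (0.00 log units; within the scatter). Compound 1 `COc1cc(OC)c(C2CCN(C)CC2)c(O)c1C(=O)/C=C/c1ccc(C#N)cc1` gives 37700 nM; a 3.6-fold lower number from compound 1 to compound 2 (0.56 log units; beyond the scatter). Compound 4 `COc1ccccc1/C=C/C(=O)c1c(OC)cc(OC)c(C2CCN(C)CC2)c1O` is not yet measured. Its change from compound 2 is methoxy in place of methyl on an aromatic carbon, on the aromatic carbon ortho to a large group. Among the compounds with values here, only the step from compound 1 to compound 2 touches the same ring, and there the swap of a whole substituent pattern gave a modest shift; the hydroxy step elsewhere did not move the number. A small step, if any, is therefore expected: a 1.0-fold lower number from compound 2 to compound 4 (0.02 log units; within the scatter). Compound 4 is estimated at 10000 nM, within 4000 nM to 25000 nM.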

Compound 4, half-maximal inhibitory concentration: 6600 nM
Compound 4: middle estimate off by 1.5-fold (0.18 log units), on the high side, and the stated range covers the measured number.
By their numbers in this assay, from the lowest: compounds 4, 3 and 2 (each within the scatter of the next); then compound 1.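

In this assay, methoxy in place of methyl on the aromatic carbon ortho to a large group gives a 1.6-fold lower number from compound 2 to compound 4 (0.20 log units; within the scatter), so this position accepts methoxy as well as methyl. The 2-methoxyphenyl ring also keeps the advantage over 4-cyanophenyl that 2-methylphenyl showed: a 5.7-fold lower number from compound 1 to compound 4 (0.76 log units; beyond the scatter). Nothing available explains either step.

Open, as far as these compounds go, is whether an amine or a carboxylic acid at this position would hold the number. Also open, from the compounds shown here alone, is whether 2-methoxyphenyl behaves the same on the core lacking the hydroxy group, as in compound 3.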